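A few compounds are considered here, and "the series" means these few. Any claim that something is new, unique, unknown or untested is made for them only; others in the source may bear on it.

For the measured compounds named here, in a functional assay on SK-LU-1 cells (Homo sapiens) for cytotoxicity, read by sulforhodamine B assay, with a stated time of 48 h (a lower number here means a stronger inhibitor, a higher number a weaker inhibitor), compound 3 `Cc1ccc(Nc2nccc(-c3c(C)nc4ccccn34)n2)cc1` gives 19.7 nM, the lowest number measured so far, while compound 1 `Cc1ccc(Nc2nccc(-c3ccnc4ccccc34)n2)cc1` gives 1400 nM. For compound 2 `Nc1nccc(-c2ccnc3ccccc23)n1` the reading is only a limit of the assay, > 50000 nM. Compound 4 `Cc1nc2ccccn2c1-c1ccnc(Nc2ccc(C=O)s2)n1` differs from compound 3 by having 5-formylthiophen-2-yl in place of 4-methylphenyl on a nitrogen on an aromatic ring. Going by the values given here, the one measured step at this place is large: an at least 35-fold higher number from compound 1 to compound 2 (1.55 log units; beyond the scatter). There, however, hydrogen replaces 4-methylphenyl, so the ring is lost altogether, whereas compound 4 keeps a ring. A much smaller rise, still beyond the scatter, is therefore expected, estimated as a 4.1-fold higher number from compound 3 to compound 4 (0.61 log units; beyond the scatter). For compound 4 the expected value is 80 nM, with an estimated range of 15 nM to 600 nM.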

Compound 4, half-maximal inhibitory concentration: 1540 nM
The estimate for compound 4 lay 19-fold (1.28 log units) below the measured number; measured number above the stated range.
By their numbers in this assay, from the lowest: compound 3; then compounds 1 and 4 (each within the scatter of the next). At a limit, above all of these: compound 2.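

Keeping a ring on this nitrogen does not by itself keep the low number: 5-formylthiophen-2-yl has the same heavy-atom count as 4-methylphenyl, yet in this assay the change gives a 78-fold higher number from compound 3 to compound 4 (1.89 log units; beyond the scatter). The earlier step at this place removed the ring altogether, whereas this one shows that the position also responds to which ring is present and what it carries. Nothing shown accounts for the size of this rise.

The ring and the formyl group change together here, so their shares cannot be separated. A plain thiophen-2-yl group, or a carboxylic acid in place of the formyl group, would be the direct test.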